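This account rests on a few compounds, and the source may have more. Where it says the series, first, only, none or still open, it means among the compounds named here.

Measured compounds: compound 1 `CCCCCCCCCO[C@@H]1[C@@H](N)[C@@H](O[C@H]2[C@H](O)[C@@H](OCCCCCCCCC)[C@H](N)C[C@@H]2N)O[C@H](CN)[C@H]1O`, 86.7%; compound 2 `CCCCCCCCCCCO[C@@H]1[C@@H](O)[C@H](O[C@H]2O[C@H](CN)[C@@H](O)[C@H](OCCCCCCC)[C@H]2N)[C@@H](N)C[C@H]1N`, 82.9%.

In an ADME assay on J774 cells (Mus musculus) for cytotoxicity, read by MTT assay, with a stated time of 24 h, tested at 10 uM (on this read-out higher numbers stand for a weaker effect at the one concentration tested and lower numbers for a stronger effect), compound 2 gives 82.9%, and compound 1 gives 86.7%; the two numbers lie within the usual scatter of each other, so neither stands apart. Compound 3 `CCCCCCCO[C@@H]1[C@@H](N)[C@@H](O[C@H]2[C@H](O)[C@@H](OCCCCCCC)[C@H](N)C[C@@H]2N)O[C@H](CN)[C@H]1O` differs from compound 2 by hydrogen in place of butyl on a saturated chain carbon, seven bonds along the chain from an oxygen on a saturated carbon. Going by the values given here, no pair of measured compounds shows this change, so its effect in this assay is unknown from the data at hand; the step is expected to be small, with no firm direction, and not beyond the scatter. Compound 3 is estimated at 86%, with a range of 74% to 98%, the expected step being a number 3.1 percentage points higher from compound 2 to compound 3 (within the scatter).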

Compound 3, a percentage reported as activity, at one concentration (the size of the read-out at that concentration, not a potency): 96.3%
Compound 3: middle estimate off by 10.3 percentage points, on the low side; the measured number falls inside the stated range.
By their numbers in this assay, from the lowest: compounds 2, 1 and 3 (each within the scatter of the next, the first and the last beyond it).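

In this assay, going by these compounds alone, replacing butyl with hydrogen on a saturated chain carbon, seven bonds along the chain from an oxygen on a saturated carbon, gives the first reading of this change (a number 13.4 percentage points higher from compound 2 to compound 3 (beyond the scatter)). The position is therefore not silent, since removing the butyl moves the number towards a weaker effect, though this rests on one pair alone. Nothing measured here explains the step. As far as these compounds go, whether an amine, a carboxylic acid or a longer chain at this place would move the number in the same direction remains open.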